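Benzyl(propyl)amino in place of the cyclic amine on compound 3

The compounds below may be only part of what the source reports. "The series", "measured", "known", "first", "only" and "open" are said of these compounds alone.

Of the compounds shown here, three have been measured in an assay on HEK293 cells for inhibition of Steryl-sulfatase (Homo sapiens), tested at 1 uM; on this read-out lower numbers stand for a weaker effect and higher numbers for a stronger effect at the one concentration tested. Compound 1 `NS(=O)(=O)Oc1ccc2c(c1)CN(C(=O)c1cccc(N(Cc3ccccc3)Cc3ccco3)c1)CC2` gives 90.5% in this assay, compound 2 `CCCN(CCC)c1cccc(C(=O)N2CCc3ccc(OS(N)(=O)=O)cc3C2)c1` gives 54.8%, and compound 3 `NS(=O)(=O)Oc1ccc2c(c1)CN(C(=O)c1cccc(N3CCc4ccccc4C3)c1)CC2` gives 50.2%. Compound 3 thus stands at the lowest of the three numbers; its nearest neighbour is compound 2, which lies within the scatter of it, while compound 1 lies beyond the scatter above it. Among the measured compounds shown here, the one single-point step so far, a number 4.6 percentage points lower from compound 2 to compound 3 (within the scatter), shows that exchanging dipropylamino for 1,2,3,4-tetrahydroisoquinolin-2-yl changed nothing beyond the scatter.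

Compound 4 `CCCN(Cc1ccccc1)c1cccc(C(=O)N2CCc3ccc(OS(N)(=O)=O)cc3C2)c1` is not yet measured. It differs from compound 3 in one place: benzyl(propyl)amino in place of 1,2,3,4-tetrahydroisoquinolin-2-yl on an aromatic carbon. The step from compound 2 to compound 3 bears on this change, since it too touches the amine on that aromatic carbon, and it was flat. The values of compound 1 and compound 2, taken on their own, show that a group carrying an aromatic ring on that nitrogen went with the higher number and the open chain with the lower. For compound 4 the expected step is therefore a number 19.8 percentage points higher from compound 3 to compound 4 (beyond the scatter), upward but uncertain. The estimate for compound 4 in this assay is 70%, with a range from 50% to 90%.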

Compound 4, a percentage reported as inhibition, at one concentration (the size of the read-out at that concentration, not a potency): 67.4%
Beside the measured number, compound 4's estimate is 2.6 percentage points above it; measured number inside the range.
By their numbers in this assay, from the lowest: compounds 3 and 2 (each within the scatter of the next); then compound 4; then compound 1.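

In this assay, benzyl(propyl)amino in place of 1,2,3,4-tetrahydroisoquinolin-2-yl gives a number 17.2 percentage points higher from compound 3 to compound 4 (beyond the scatter); both groups carry a six-membered aromatic ring of carbon only, so the presence of that ring alone does not fix the number at this position, and the open and cyclic amines are not interchangeable here. On the open amine, phenyl in place of ethyl on the saturated chain carbon gives a number 12.6 percentage points higher from compound 2 to compound 4 (beyond the scatter), the first single-place sign that an aromatic ring on that chain raises the number, whereas ethyl in place of furan-2-yl gives a number 23.1 percentage points lower from compound 1 to compound 4 (beyond the scatter), so the propyl arm also leaves part of the effect unreached. No measured data are at hand to explain any of these steps.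

Still open, as far as these compounds go, is whether the furan-2-yl ring itself matters or whether any second aromatic ring would serve, which a thiophen-2-yl, a pyridin-2-yl or a plain phenyl on that arm would test. Also open, from the compounds shown here alone, is how far the benzyl ring tolerates substitution, for instance a methoxy group or a carboxylic acid on it.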